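The source may hold more compounds than are shown below. What is called first, only, known or untested is meant among the compounds shown, and "the series" means these compounds.

Compound 3, `CC(Sc1nc2c(cnn2C)c(=O)n1-c1ccccc1)c1ccccc1`, is the reference point of this step. In an assay on isolated protein for inhibition of Retinaldehyde dehydrogenase 3 (Homo sapiens) (on this read-out lower numbers stand for stronger inhibition and higher numbers for weaker inhibition), compound 3 gives 73 nM. Its two measured neighbours sit within the scatter of that figure: compound 1, `CC(Sc1nc2c(cnn2C)c(=O)n1-c1ccccc1)c1ccccn1`, gives 89 nM, and compound 2, `CC(Sc1nc2c(cnn2C)c(=O)n1-c1ccccc1)c1cccc(F)c1`, gives 128 nM. The three steps connecting them, a 1.2-fold lower number from compound 1 to compound 3 (0.09 log units; within the scatter), a 1.4-fold higher number from compound 1 to compound 2 (0.16 log units; within the scatter) and a 1.8-fold lower number from compound 2 to compound 3 (0.24 log units; within the scatter), all stay within the scatter, so the measured set shows a flat response to the group on the saturated chain carbon bound to a saturated chain carbon and a sulfur.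

Compound 4, `CC(Sc1nc2c(cnn2C)c(=O)n1-c1ccccc1)c1cncnc1`, carries the change (pyrimidin-5-yl in place of phenyl on a saturated chain carbon bound to a saturated chain carbon and a sulfur). The step that bears most directly on it is a 1.2-fold lower number from compound 1 to compound 3 (0.09 log units; within the scatter), where a ring with one nitrogen and one without differed by nothing beyond the scatter. Among the compounds with values here, no measured compound carries a ring with two nitrogens at this place, so the expectation rests on that single precedent. A step of roughly a 1.5-fold higher number from compound 3 to compound 4 (0.18 log units; within the scatter) is therefore expected, with no direction established beyond the scatter. Compound 4 is estimated at 110 nM, within the range 45 nM to 280 nM.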

Compound 4, half-maximal inhibitory concentration: 100 nM
For compound 4 the middle estimate is 1.1-fold (0.04 log units) above the measured one; measured number inside the range.
By their numbers in this assay, from the lowest: compounds 3, 1, 4 and 2 (each within the scatter of the next).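

In this assay, pyrimidin-5-yl at the saturated chain carbon bound to a saturated chain carbon and a sulfur fits the flat response of the earlier groups: the steps (a 1.4-fold higher number from compound 3 to compound 4 (0.14 log units; within the scatter)), (a 1.3-fold lower number from compound 2 to compound 4 (0.11 log units; within the scatter)) and (a 1.1-fold higher number from compound 1 to compound 4 (0.05 log units; within the scatter)) all stay within the scatter. Within the data shown here, that flat response now also covers the exchange of phenyl, with 0 hydrogen-bond acceptors, for a ring with 2 hydrogen-bond acceptors, and no compound among the four stands apart from the others. Nothing measured here accounts for this flat response.

All four groups at this place are six-membered aromatic rings, so the compounds shown leave open how a cyclohexyl group, an amine or a carboxylic acid there would read. They also leave open whether a longer chain in place of the methyl on that saturated carbon would change the number.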